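From 3-methylphenyl to 4-iodophenyl in an antiproliferative series

A few compounds are considered here, and "the series" means these few. Any claim that something is new, unique, unknown or untested is made for them only; others in the source may bear on it.

Measured in a functional assay on MCF7 cells (Homo sapiens) for antiproliferative activity, read by MTT assay, with a stated time of 48 h; on this read-out lower numbers stand for stronger inhibition and higher numbers for weaker inhibition
- Compound 1 `Cc1ccc2nc(NC(c3cn(-c4ccccc4)nc3-c3cccc(Cl)c3)c3c(O)ccc4ccccc34)sc2c1` gives 49700 nM
- Compound 2 `Cc1cc2nc(NC(c3cn(-c4ccccc4)nc3-c3ccc([N+](=O)[O-])cc3)c3c(O)ccc4ccccc34)sc2cc1C` gives 41100 nM
- Compound 3 `Cc1cccc(-c2nn(-c3ccccc3)cc2C(Nc2nc3ccccc3s2)c2c(O)ccc3ccccc23)c1` gives 17300 nM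

Compound 3 has the lowest number of the three, and its gaps to compound 2 and compound 1 lie beyond the usual scatter. Compound 4 `Oc1ccc2ccccc2c1C(Nc1nc2ccccc2s1)c1cn(-c2ccccc2)nc1-c1ccc(I)cc1` remains unmeasured and carries 4-iodophenyl in place of 3-methylphenyl on an aromatic carbon. Among the compounds with values here, no measured pair isolates a change at this place. Compound 1 at 49700 nM and compound 2 at 41100 nM both stand higher, though each differs from compound 3 in more than one place. In this assay a small move towards a higher number is therefore expected, or none beyond the scatter. The estimated 1.5-fold higher number from compound 3 to compound 4 (0.18 log units; within the scatter) reflects this. For compound 4 the expected value is 26000 nM, with an estimated range from 11000 nM to 60000 nM.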

Compound 4, half-maximal inhibitory concentration: 18900 nM
Compound 4: middle estimate off by 1.4-fold (0.14 log units), on the high side; the range from low to high includes it.
By their numbers in this assay, from the lowest: compounds 3 and 4 (each within the scatter of the next); then compounds 2 and 1 (each within the scatter of the next).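

In this assay, within the data shown here, putting 4-iodophenyl in place of 3-methylphenyl gives a 1.1-fold higher number from compound 3 to compound 4 (0.04 log units; within the scatter), the first pair to isolate a change at this place on the five-membered ring. On this read-out, these two aromatic groups, each of 7 heavy atoms, cannot be told apart here. Nothing at hand explains this result. The compounds shown leave open whether an amine, a carboxylic acid or a longer chain at this place would shift the number beyond the scatter. They also leave open whether this exchange would give a similar result on a different core.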